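Replacing Benzyl with Pyridinylmethyl in a 24-Hydroxylase Inhibitor

The source may report more compounds than this note shows. Statements on the series, on what has been measured and on what is new or still open speak of the compounds shown alone.

For the measured compounds named here, compound 1 `O=C(c1ccccc1-c1ccncn1)N1CCC(O)(Cc2ccccc2)CC1` is one of two compounds measured in an assay for inhibition of cholesterol 24-hydroxylase (Homo sapiens), using NADPH, with stated times of 15 min and 5 min; a lower number here means a stronger inhibitor, a higher number a weaker inhibitor. In this assay compound 1 gives 4.3 nM, the lowest number of the pair. Compound 2 `O=C(c1cccnc1-c1ccncc1)N1CCC(O)(Cc2ccccn2)CC1` differs from compound 1 in more than one place; in this assay compound 2 gives 100 nM, a higher number, and the gap between the two lies beyond the scatter. Compound 3 `O=C(c1ccccc1-c1ccncn1)N1CCC(O)(Cc2ccccn2)CC1` has not been measured. It departs from compound 1 by a single change: pyridin-2-yl in place of phenyl on a saturated chain carbon bound to a saturated ring carbon. Going by the values given here, no measured pair in this set isolates that change, so its effect can only be estimated. Since compound 2 carries the same pyridin-2-yl group along with a second change and gives 100 nM, a modest weakening is expected, and the step from compound 1 to compound 3 is estimated at a 2.8-fold higher number from compound 1 to compound 3 (0.45 log units; beyond the scatter). Compound 3 is therefore expected to give about 12 nM, within a range of 4 nM to 40 nM.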

Compound 3, half-maximal inhibitory concentration: 36 nM
Estimate against measurement, compound 3: 3.0-fold (0.48 log units) below, within the range that was stated.
By their numbers in this assay, from the lowest: compound 1; then compound 3; then compound 2.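

For the compounds shown here, compound 3 gives the first reading of this change on its own: in this assay, pyridin-2-yl in place of phenyl on a saturated chain carbon bound to a saturated ring carbon brings an 8.4-fold higher number from compound 1 to compound 3 (0.92 log units; beyond the scatter). The rest of compound 1 stays the same and the heavy-atom count of the group does not change, so swapping benzyl for (pyridin-2-yl)methyl is enough by itself to weaken inhibition beyond the scatter. No measurement shown explains this loss.

As far as these compounds go, whether pyridin-3-yl or pyridin-4-yl at this place would give a similar number remains open. So does the effect of a fluorine or a methoxy group on the phenyl ring of compound 1.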